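Urea-linked quinazoline series: methyl to methoxy at the terminal ring

A few compounds are considered here, and "the series" means these few. Any claim that something is new, unique, unknown or untested is made for them only; others in the source may bear on it.

Measured so far:
- compound 1, `COc1cc2ncnc(NCc3cccc(NC(=O)Nc4cccc(C)c4)c3)c2cc1OC`: 44600 nM
- compound 2, `COc1cc2ncnc(NCc3cccc(NC(=O)Nc4ccc(C)cc4)c3)c2cc1OC`: 34200 nM

In a functional assay on MGC-803 cells (Homo sapiens) for antiproliferative activity, read by MTT assay (a higher number here means a weaker inhibitor, a lower number a stronger inhibitor), compound 2 gives the lower of the two numbers, but the step of a 1.3-fold lower number from compound 1 to compound 2 (0.12 log units; within the scatter) is within the scatter, so compound 1 and compound 2 cannot be told apart on these numbers. Compound 3, `COc1ccc(NC(=O)Nc2cccc(CNc3ncnc4cc(OC)c(OC)cc34)c2)cc1`, has not been measured. It differs from compound 2 in one place: methoxy in place of methyl on an aromatic carbon. For the measured compounds named here, no measured step matches this change; the only step recorded, from compound 1 to compound 2, moves a methyl around the same ring and stays within the scatter. On that basis nothing beyond the scatter is expected for compound 3, and the step of a 1.1-fold lower number from compound 2 to compound 3 (0.03 log units; within the scatter) is taken as an estimate only. Compound 3 is therefore expected at about 32000 nM, within a range of 12000 nM to 80000 nM.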

Compound 3, half-maximal inhibitory concentration: 12300 nM
For compound 3 the middle estimate is 2.6-fold (0.42 log units) above the measured one, and the stated range covers the measured number.
By their numbers in this assay, from the lowest: compound 3; then compounds 2 and 1 (each within the scatter of the next).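

In this assay the terminal ring proves sensitive to the group on this aromatic carbon, para to a large group: methoxy in place of methyl gives a 2.8-fold lower number from compound 2 to compound 3 (0.44 log units; beyond the scatter), whereas the earlier methyl shift gave only a 1.3-fold lower number from compound 1 to compound 2 (0.12 log units; within the scatter) and could not separate its two compounds. The change from 3-methylphenyl to 4-methoxyphenyl gives a 3.6-fold lower number from compound 1 to compound 3 (0.56 log units; beyond the scatter), so compound 3 has the lowest number of the three, with both of its steps beyond the scatter, though both are modest in size. Nothing available here accounts for the step.

As far as these compounds go, whether a hydroxyl, ethoxy or dimethylamino group on the same carbon would move the number further remains open. Also open, from the compounds shown here alone, is whether the methyl-to-methoxy step would carry over to analogues with a different core.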